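Extending the amide chain of compound 2

The source may hold more compounds than are shown below. What is called first, only, known or untested is meant among the compounds shown, and "the series" means these compounds.

Among the compounds with values here, only two compounds have numbers so far. In a functional assay on HeLa cells (Homo sapiens) for antiproliferative activity, read by CCK-8 assay, with a stated time of 72 h (on this read-out lower numbers stand for stronger inhibition of growth and higher numbers for weaker inhibition of growth), compound 1 (`CC[C@@H]1C(=O)N(C)c2cnc(-n3ccc4cc(C(N)=O)ccc43)nc2N1C1CCCC1`) gives 674 nM as its value. In this assay compound 2 (`CCC1C(=O)N(C)c2cnc(-n3ccc4cc(C(=O)NC)ccc43)nc2N1c1ccn(C)n1`) gives 6330 nM as its value, the higher of the two numbers and so the weaker inhibition of growth, with a gap beyond the usual scatter.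

Compound 3 (`CCCNC(=O)c1ccc2c(ccn2-c2ncc3c(n2)N(c2ccn(C)n2)C(CC)C(=O)N3C)c1`) departs from compound 2 in one place. The change, ethyl in place of hydrogen on a saturated chain carbon bound to an amide-type nitrogen, reads as methylcarbamoyl to propylcarbamoyl and counts as ethyl in place of hydrogen on a saturated chain carbon bound to an amide-type nitrogen in all.

Within the data shown here, no measured pair isolates this change, so the expectation in this assay is loose: no step beyond the scatter, with a slight lean towards a higher number. The expected shift is a 1.3-fold higher number from compound 2 to compound 3 (0.10 log units; within the scatter) as an estimate. For compound 3 the estimated value is 8000 nM with 2500 nM to 25000 nM as the expected range.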

Compound 3, concentration for 50% growth inhibition: 6160 nM
Estimate against measurement, compound 3: 1.3-fold (0.11 log units) above; measured number inside the range.
By their numbers in this assay, from the lowest: compound 1; then compounds 3 and 2 (each within the scatter of the next).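

Within the data shown here, the change from methylcarbamoyl to propylcarbamoyl is the first one that a measured pair isolates, and in this assay it gives a 1.0-fold lower number from compound 2 to compound 3 (0.01 log units; within the scatter). Among these compounds, on this pair, then, the amide chain of compound 2 takes ethyl in place of hydrogen on the saturated chain carbon bound to the amide-type nitrogen with no step in growth inhibition that can be told from the scatter. No measurement at hand bears on why the number holds steady across this change.

The compounds shown leave open whether a longer chain, such as hexyl, or a propyl chain ending in an amine or a carboxylic acid, would also leave the number in place. This single step also cannot say whether the same change would read alike on any compound other than compound 2.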